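The source may hold more compounds than are shown below. What is called first, only, known or untested is meant among the compounds shown, and "the series" means these compounds.

In a functional assay on MIA PaCa-2 cells (Homo sapiens) for cytotoxicity, read by WST assay, with a stated time of 48 h (on this read-out higher numbers stand for weaker inhibition and lower numbers for stronger inhibition), compound 1 `COc1ccc2[nH]cc(C(=O)/C(C#N)=C/c3c[nH]c4cc(F)ccc34)c2c1` gives > 50000 nM as a limit of the assay and not a number. Compound 3 `COc1ccc(-c2[nH]c3ccccc3c2/C=C(\C#N)C(=O)c2c[nH]c3ccccc23)cc1` likewise gives > 50000 nM as a limit. Within the data shown here, compound 2 `N#C/C(=C\c1cn(Cc2ccc(Cl)cc2)c2ccccc12)C(=O)c1c[nH]c2cc(F)ccc12` gives 16600 nM as the only actual number among the three. Compound 4 `N#C/C(=C\c1cn(Cc2ccc(Cl)cc2)c2ccccc12)C(=O)c1c[nH]c2ccccc12` has not yet been measured and carries hydrogen in place of fluoro on an aromatic carbon of compound 2, a change counted as hydrogen in place of fluoro on an aromatic carbon and read as 6-fluoro-1H-indol-3-yl to 1H-indol-3-yl. Among the measured compounds shown here, no measured pair of compounds shows this change. No step beyond the usual scatter is expected in this assay in either direction, leaving compound 2 at 16600 nM as the anchor for the expectation. For compound 4 the estimated value is 16000 nM with an expected range from 6000 nM to 45000 nM as the likely span. The expected 1.0-fold lower number from compound 2 to compound 4 (0.02 log units; within the scatter) is a small one.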

Compound 4, half-maximal inhibitory concentration: > 50000 nM
Compound 4: a limit, no number (the forecaster's own chance of this, stated with the estimate: 15%); middle value at least 3.1-fold (0.49 log units) from the limit.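

Replacing the fluoro of 6-fluoro-1H-indol-3-yl with hydrogen gives an at least 3.0-fold higher number from compound 2 to compound 4 (0.47 log units; beyond the scatter) in this assay, the first step seen at this position. On this pair, then, losing the fluoro weakens inhibition, and even a change of a single atom on this aromatic carbon can be read beyond the scatter. Compound 4 gives > 50000 nM, a limit of the assay and not a number, so the full size of the step stays unknown: the limit of > 50000 nM in this assay, at which 3 of the 4 values shown sit.

As far as these compounds go, whether a hydroxyl or an amine at this place would keep any of the activity of compound 2 remains open. One pair also cannot tell whether the fluoro counts the same way with other groups elsewhere on the core.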